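Imidazoline series: thiophenylmethyl variant of compound 3

The compounds below may be only part of what the source reports. "The series", "measured", "known", "first", "only" and "open" are said of these compounds alone.

Compound 3 `C=C(C)CN(C1=NCCN1)c1c(Br)cccc1Br` gives -0.66 in a physicochemical assay for lipophilicity (a higher number here means a more lipophilic compound, a lower number a more polar compound), the second highest of three numbers. Compound 1 `Brc1ccc(Br)c(N(CC2CC2)C2=NCCN2)c1` gives -0.52, within the scatter of compound 3. Among the compounds with values here, compound 2 `CCCCN(C1=NCCN1)c1c(Br)cccc1Br` gives -2.5, and the single measured step, a number 1.84 log units higher from compound 2 to compound 3 (beyond the scatter), is large. Compound 4 `Brc1cccc(Br)c1N(Cc1cccs1)C1=NCCN1` differs from compound 3 by thiophen-2-yl in place of 1-methylethenyl on a saturated chain carbon bound to a nitrogen on an aromatic ring. Within the data shown here, no measured step covers bringing in a five-membered aromatic ring with one hetero atom; the step from compound 2 to compound 3 concerns a different change and offers no direct guide. The expectation is therefore a moderate step of a number 0.46 log units higher from compound 3 to compound 4 (beyond the scatter) with wide uncertainty. Compound 4 is estimated at -0.2, expected between -1.1 and 0.7.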

Compound 4, distribution coefficient: -0.1
Compound 4: middle estimate off by 0.10 log units, on the low side; low and high end bracket the measured number.
By their numbers in this assay, from the lowest: compound 2; then compounds 3 and 1 (each within the scatter of the next); then compound 4.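

On the saturated chain carbon bound to a nitrogen on an aromatic ring, thiophen-2-yl in place of 1-methylethenyl gives in this assay a number 0.56 log units higher from compound 3 to compound 4 (beyond the scatter), so a five-membered aromatic ring with one hetero atom is a further rise at this place. Against propyl, thiophen-2-yl gives a number 2.40 log units higher from compound 2 to compound 4 (beyond the scatter), the largest step shown in this series. Nothing at hand accounts for either step. From the compounds shown here alone, whether phenyl or a longer chain at this place would match thiophen-2-yl stays open. So does the effect of an amine or a carboxylic acid there.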